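Cytotoxicity of a benzamide series: phenoxy to methoxy

A few compounds are considered here, and "the series" means these few. Any claim that something is new, unique, unknown or untested is made for them only; others in the source may bear on it.

Of the compounds shown here, three from this series have been tested in an ADME assay on BJ cells (Homo sapiens) for cytotoxicity, read by CellTiter-Glo and resazurin assay, with a stated time of 72 h; on this read-out lower numbers stand for an effect already at smaller amounts and higher numbers for an effect only at larger amounts of compound. Compound 1 `CCOC(=O)CCCCCOc1cccc(CN(C(=O)c2ccc(-c3cnc(OC)nc3OC)cc2)C(C)C)c1` gives only a limit of the assay, > 26000 nM. Compound 2 `CCOC(=O)CCCCCOc1cccc(CN(C(=O)c2ccc(-c3ccco3)cc2)C(C)C)c1` likewise gives only a limit, > 26000 nM. The step that the two limits leave unreadable from compound 1 to compound 2 therefore cannot be read. Compound 3 `CCOC(=O)CCCCCOc1cccc(CN(C(=O)c2ccc(-c3cccc(Oc4ccccc4)c3)cc2)C(C)C)c1` also returns only a limit in this assay, > 19600 nM. Compound 3 thus stands where every measured value stands: at a limit, with no number; two of the values sit at the limit of > 26000 nM in this assay, at which 2 of the 3 values shown sit, and one at the limit of > 19600 nM in this assay, at which 1 of the 3 values shown sits.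

Compound 4 `CCOC(=O)CCCCCOc1cccc(CN(C(=O)c2ccc(-c3cccc(OC)c3)cc2)C(C)C)c1` differs from compound 3 by methyl in place of phenyl on an oxygen on an aromatic ring. Going by the values given here, no measured step in this assay carries a readable size, and all three measured compounds sit at limits, so no step in either direction beyond the scatter is expected. Compound 4 is therefore expected to give 30000 nM in this assay, with a range from 12000 nM to 100000 nM, and the step that the limit leaves unreadable from compound 3 to compound 4 is expected to stay within the scatter, most probably as another limit.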

Compound 4, half-maximal effective concentration: > 21000 nM
Compound 4: no number, only a limit; the forecaster's own chance of this, stated with the estimate: 85%; the middle value does not contradict the limit.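

In this assay, going by these compounds alone, compound 4 gives only a limit, as do compound 1, compound 2 and compound 3, so no step from any of these to compound 4 can be read. The compounds shown leave open whether the groups exchanged among them change cytotoxicity at all.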